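This account rests on a few compounds, and the source may have more. Where it says the series, first, only, none or still open, it means among the compounds named here.

Measured in an ADME assay on HepG2 cells (Homo sapiens) for cytotoxicity, read by CellTiter-Glo, with a stated time of 48 h; on this read-out higher numbers stand for lower toxicity in this test and lower numbers for higher toxicity in this test:
Compound 1 `CCCCNc1nc2ccccc2nc1S(C)(=O)=O`: 12600 nM
Compound 2 `CCCCNc1nc2cc(OC)ccc2nc1S(C)(=O)=O`: > 100000 nM, a limit of the assay
Compound 3 `CCCCNc1nc2cc(Br)ccc2nc1S(C)(=O)=O`: 7940 nM

Among the measured compounds shown here, the only number near compound 3 is that of compound 1. That gap is a 1.6-fold lower number from compound 1 to compound 3 (0.20 log units; within the scatter). The methoxy steps are much larger: an at least 7.9-fold higher number from compound 1 to compound 2 (0.89 log units; beyond the scatter), and an at least 12-fold lower number from compound 2 to compound 3 (1.10 log units; beyond the scatter).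

Compound 4 `CCCCNc1nc2cc(Cl)ccc2nc1S(C)(=O)=O` carries chloro in place of bromo on an aromatic carbon. The bromo step bears most directly on this change, and the methoxy steps concern a different group. For the measured compounds named here, no step between two halogens has been measured. In this assay, no change beyond the scatter is expected. The expected step is a 1.3-fold higher number from compound 3 to compound 4 (0.10 log units; within the scatter). For compound 4 the estimate is 10000 nM, with an expected range of 4500 nM to 22000 nM.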

Compound 4, half-maximal cytotoxic concentration: 6310 nM
For compound 4 the middle estimate is 1.6-fold (0.20 log units) above the measured one; the range from low to high includes it.
By their numbers in this assay, from the lowest: compounds 4, 3 and 1 (each within the scatter of the next). At a limit, above all of these: compound 2.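

In this assay, among the compounds shown here, the step between the two halogens at this place is small, with a 1.3-fold lower number from compound 3 to compound 4 (0.10 log units; within the scatter) as the only such comparison. Chloro also shows a 2.0-fold lower number from compound 1 to compound 4 (0.30 log units; within the scatter) against hydrogen, so, like bromo, it does not separate from hydrogen beyond the scatter. Methoxy remains apart, with an at least 15-fold lower number from compound 2 to compound 4 (1.19 log units; beyond the scatter), but this step rests on a limit for compound 2: the limit of > 100000 nM in this assay, at which 1 of the 4 values shown sits.

On these data alone, whether an amine or a carboxylic acid at this place would also stand apart from hydrogen remains open. So does whether these small halogen steps would hold with a longer chain on the nitrogen.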